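A few compounds are considered here, and "the series" means these few. Any claim that something is new, unique, unknown or untested is made for them only; others in the source may bear on it.

In a physicochemical assay for solubility (on this read-out higher numbers stand for higher solubility and lower numbers for lower solubility), compound 1 (`Nc1cccc2c(=O)[nH]c(-c3ccccc3)cc12`) gives > 30000000 nM as a limit, not a number. Compound 2 (`Nc1cccc2c(=O)[nH]c(-c3ccc(Cl)cc3)cc12`) gives > 30000000 nM as a limit too. Compound 3 (`Cc1cc2c(N)cccc2c(=O)[nH]1`) gives > 30000000 nM as a limit as well, so it stands at the limit of > 30000000 nM in this assay, at which 3 of the 3 values shown sit, and has no number. Compound 4 (`CCc1cc2c(N)cccc2c(=O)[nH]1`) carries one change from compound 3 (methyl in place of hydrogen on a saturated chain carbon bound to an aromatic carbon), methyl in place of hydrogen on a saturated chain carbon bound to an aromatic carbon. The measured steps (a step that the two limits leave unreadable from compound 1 to compound 3) and (a step that the two limits leave unreadable from compound 1 to compound 2) have no readable size, so neither sets a size for this change. In this assay the expected step (a number no higher from compound 3 to compound 4 (the limit leaves the size open)) stays within the scatter, in neither direction. The expected value for compound 4 is 30000000 nM (estimated range 12000000 nM to 40000000 nM), quite possibly again only a limit.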

Compound 4, solubility: > 30000000 nM
Compound 4: no number, only a limit (the forecaster's own chance of this, stated with the estimate: 80%); the middle value sits exactly at the limit.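

For the compounds shown here, compound 4 gives only a limit, like compound 3 and compound 1, so no step to compound 4 can be read. The compounds shown leave open how far their values actually differ in this assay, since all of them sit at one limit: the limit of > 30000000 nM in this assay, at which 4 of the 4 values shown sit.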